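The source may hold more compounds than are shown below. What is called first, only, known or untested is meant among the compounds shown, and "the series" means these compounds.

In a functional assay on THP-1 cells (Homo sapiens) for inhibition, read by sulforhodamine B assay, with a stated time of 48 h (on this read-out lower numbers stand for stronger inhibition and higher numbers for weaker inhibition), compound 1 `COC(=O)[C@H]1C[C@@H](c2coc3ccccc3c2=O)N(c2ccccc2)O1` gives > 60000 nM, which is a limit. Compound 2 `CCO[C@H]1C[C@@H](c2coc3ccccc3c2=O)N(c2ccccc2)O1` gives > 60000 nM, also a limit. Compound 3 `CCO[C@H]1C[C@@H](c2coc3ccc(F)cc3c2=O)N(c2ccccc2)O1` gives > 60000 nM, again a limit. Going by the values given here, the series so far rests entirely on (the limit of > 60000 nM in this assay, at which 3 of the 3 values shown sit). The next change leads to compound 4 `O=c1c([C@@H]2C[C@H](c3ccccc3)ON2c2ccccc2)coc2ccc(F)cc12`: phenyl in place of ethoxy on a saturated ring carbon, (phenyl in place of ethoxy on a saturated ring carbon). Among the compounds with values here, two measured steps bear on it: a step that the two limits leave unreadable from compound 1 to compound 2, on the same saturated ring carbon, and a step that the two limits leave unreadable from compound 2 to compound 3, on an aromatic carbon. Neither size can be read, so no defined size or direction can be expected in this assay with any confidence. The expected outcome is an at least 1.2-fold lower number from compound 3 to compound 4 (0.07 log units; that floor lies within the scatter). For compound 4 the estimate is 50000 nM, with an expected range of 15000 nM to 100000 nM.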

Compound 4, half-maximal inhibitory concentration: 54700 nM
Compound 4: middle estimate off by 1.1-fold (0.04 log units), on the low side, and the stated range covers the measured number.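

Going by these compounds alone, with phenyl on the saturated ring carbon next to the ring oxygen, compound 4 gives 54700 nM in this assay, the only value shown that is a number and not a limit. The change gives an at least 1.0-fold lower number from compound 3 to compound 4 (0.04 log units; that floor lies within the scatter), so this position can yield a measurable number, but no real gain can be claimed. The other steps cannot be read, and the rest of the series sits at a limit: the limit of > 60000 nM in this assay, at which 3 of the 4 values shown sit.

Open, going by these compounds, is whether an amine or a carboxylic acid on this carbon would move the number beyond the scatter from compound 4. Also open, on these data alone, is what the fluoro on the aromatic carbon contributes alongside phenyl.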